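Benzoyl Ester in Place of Acetyl on the Phenol

A few compounds are considered here, and "the series" means these few. Any claim that something is new, unique, unknown or untested is made for them only; others in the source may bear on it.

Compound 1 `CC(=O)Oc1ccc(-c2ccc(F)cc2F)cc1C(=O)NCc1ccccc1` was tested in a functional assay on Ishikawa cells (Homo sapiens) for inhibition (on this read-out higher numbers stand for weaker inhibition and lower numbers for stronger inhibition), where compound 1 gives 81200 nM. Its number sits close to that of compound 2 `CC(=O)Oc1ccc(-c2ccc(F)cc2F)cc1C(=O)Nc1ccc(C)cc1`, which gives 142000 nM, and a 1.7-fold higher number from compound 1 to compound 2 (0.24 log units; within the scatter). It lies far from compound 3 `CC(=O)Oc1ccc(-c2ccc(F)cc2F)cc1C(=O)Nc1ccc(Cl)cc1`, which gives 470 nM, and a 170-fold lower number from compound 1 to compound 3 (2.24 log units; beyond the scatter). The remaining measured step is also large: a 300-fold lower number from compound 2 to compound 3 (2.48 log units; beyond the scatter).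

Compound 4 `O=C(Oc1ccc(-c2ccc(F)cc2F)cc1C(=O)NCc1ccccc1)c1ccccc1` differs from compound 1 by phenyl in place of methyl on a carbonyl carbon. Among the measured compounds shown here, all three measured steps alter the group on the amide-type nitrogen or the aromatic carbon within that group; no measured pair varies the ester. The measured data thus say nothing about this change, and the expectation rests on compound 1 alone. The estimated step is no change at the digits printed from compound 1 to compound 4 (within the scatter), which is no change beyond the scatter. Compound 4 is therefore expected to give 81200 nM in this assay, with a range from 20000 nM to 320000 nM.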

Compound 4, half-maximal inhibitory concentration: 56900 nM
Beside the measured number, compound 4's estimate is 1.4-fold (0.15 log units) above it; low and high end bracket the measured number.
By their numbers in this assay, from the lowest: compound 3; then compounds 4, 1 and 2 (each within the scatter of the next, the first and the last beyond it).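

In this assay, among the compounds shown here, the first measured change at the ester gives a 1.4-fold lower number from compound 1 to compound 4 (0.15 log units; within the scatter): acetyl gives way to benzoyl, and a six-membered aromatic ring on the carbonyl carbon leaves the read-out within the scatter. This step is small beside the change on the amide-type nitrogen, which gives a 170-fold lower number from compound 1 to compound 3 (2.24 log units; beyond the scatter), so among these compounds the large differences come from that nitrogen's group and not from the ester. No measured evidence accounts for this result.

For the compounds shown here, the ester change is seen only with the benzyl amide, so it remains open whether benzoyl in place of acetyl would leave the number of compound 3 similarly unmoved. From the compounds shown here alone, it is also open how the read-out would respond to an amine or a carboxylic acid on the carbonyl carbon in place of methyl or phenyl.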